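A few compounds are considered here, and "the series" means these few. Any claim that something is new, unique, unknown or untested is made for them only; others in the source may bear on it.

Working notes on a small set of nucleoside analogues built on the same difluorinated sugar. Compound 1 `Nc1ccn([C@H]2CC(F)(F)[C@H](CO)O2)c(=O)n1` carries an amino group on its core; compound 2 `O=c1nc(O)ccn1[C@H]1CC(F)(F)[C@H](CO)O1` is its counterpart after (hydroxy in place of amino on an aromatic carbon). Compound 3 `Nc1ncnc2c1ncn2[C@@H]1CC(F)(F)[C@H](CO)O1` has a different core; the difference between the core of compound 1 and the core of compound 3 is not broken down here. Compound 4 `OC[C@@H]1O[C@H](n2cnc3c(O)ncnc32)CC1(F)F`, not yet measured, stands to compound 3 as compound 2 stands to compound 1: hydroxy in place of amino on an aromatic carbon. The surroundings of the place differ: in compound 3 the six-membered aromatic ring with 2 nitrogen is part of a fused or bridged system of two rings, the carbon being ortho to a fused ring and meta to a fused ring, whereas in compound 1 the carbon is meta to a group of 1 heavy atom and para to a group of 9 heavy atoms. It is therefore the same kind of change, not the same change.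

In a functional assay on Vero cells (Chlorocebus sabaeus) for cytotoxicity (a lower number here means a stronger inhibitor, a higher number a weaker inhibitor), compound 1 gives > 100000 nM, a limit of the assay and not a number. In this assay compound 2 gives > 100000 nM, likewise a limit. In this assay compound 3 gives > 100000 nM, again a limit. Hence a step that the two limits leave unreadable from compound 1 to compound 2. All three measured values sit at the limit of > 100000 nM in this assay, at which 3 of the 3 values shown sit.

For compound 4 the expected step is a number no higher from compound 3 to compound 4 (the limit leaves the size open), because compound 3 sits at the limit of > 100000 nM in this assay, at which 3 of the 3 values shown sit, and the same kind of change left compound 2 at the same limit. Compound 4 is accordingly expected to give about 100000 nM in this assay, most likely reported again only as a limit.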

Compound 4, half-maximal inhibitory concentration: > 100000 nM
Compound 4: no number, only a limit; the forecaster's own chance of this, stated with the estimate: 85%; the middle value lies on the limit itself.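

In this assay compound 4 gives > 100000 nM, a limit of the assay and not a number. Compound 3 also stands at a limit, and the step between compound 3 and compound 4 cannot be read. All values shown sit at one limit: the limit of > 100000 nM in this assay, at which 4 of the 4 values shown sit. The compounds shown leave open whether hydroxy in place of amino moves the read-out at all in this assay, and how these compounds would rank against one another.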